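This account rests on a few compounds, and the source may have more. Where it says the series, first, only, none or still open, it means among the compounds named here.

Compound 1 `COc1ccc(C2=NN(C3=NC(=O)/C(=C4\C(=O)Nc5ccc(Br)cc54)S3)C(c3ccc(OC)cc3)C2)cc1` and compound 2 `COc1ccc(C2=NN(C3=NC(=O)/C(=C4\C(=O)Nc5ccc(Cl)cc54)S3)C(c3ccc(OC)cc3)C2)cc1` share one core and differ in a single spot: chloro in place of bromo on an aromatic carbon. Both were tested in a functional assay on cells (Cancer cell lines, Homo sapiens) for cytotoxicity, read by sulforhodamine B assay, with a stated time of 48 h; on this read-out higher numbers stand for weaker inhibition of growth and lower numbers for stronger inhibition of growth. Compound 1 gives 25300 nM, while compound 2 gives 430 nM, so the swap produced a 59-fold lower number from compound 1 to compound 2 (1.77 log units; beyond the scatter).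

Compound 3 `COc1ccc(-c2cc(-c3ccc(Cl)cc3)n(C3C(=O)Nc4ccc(Br)cc43)n2)cc1` is built on a different core; the difference between the two cores is not broken down here. In this assay compound 3 gives 36300 nM, a number close to that of compound 1 and well above that of compound 2.

Compound 4 `COc1ccc(-c2cc(-c3ccc(Cl)cc3)n(C3C(=O)Nc4ccc(Cl)cc43)n2)cc1` has not yet been measured. It is related to compound 3 by exactly the change that links compound 1 to compound 2: chloro in place of bromo on an aromatic carbon. The surroundings of the swap are described in the same words for both pairs, so it counts as the same change on a different core.

For the measured compounds named here, the only guide is the pair already measured. Going by the values given here, since the step of a 59-fold lower number from compound 1 to compound 2 (1.77 log units; beyond the scatter) was large on the core of compound 1, a shift in the same direction is expected for compound 4, though with only one example it is uncertain whether a change of that size carries over to the core of compound 3. On that basis compound 4 is expected to give 4000 nM in this assay, which would mean a step of a 9.1-fold lower number from compound 3 to compound 4 (0.96 log units; beyond the scatter), with a plausible range from 500 nM to 30000 nM.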

Compound 4, concentration for total growth inhibition: 28600 nM
Beside the measured number, compound 4's estimate is 7.2-fold (0.85 log units) below it; the range from low to high includes it.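

On the core of compound 3, putting chloro in place of bromo gives a 1.3-fold lower number from compound 3 to compound 4 (0.10 log units; within the scatter) in this assay, so on this core the swap leaves no difference that can be told apart from the ordinary spread of repeated measurements. Set beside the earlier pair, the same swap does not carry over in size from one core to the other: the same change on two cores in this assay, a 59-fold lower number (1.77 log units; beyond the scatter) from compound 1 to compound 2 and a 1.3-fold lower number (0.10 log units; within the scatter) from compound 3 to compound 4, 46-fold (1.67 log units) apart, beyond the scatter of two such steps. In this series, then, the effect of this swap on one core is a poor guide to its effect on another, but two pairs do not show why the cores behave differently or what the swap would do on a third core.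

The compounds shown carry only bromo or chloro on this aromatic carbon, so it remains open what fluoro or an amine in the same place would do on either core. On these data alone, it also remains open whether such a group would again give a large step on the core of compound 1 and almost none on the core of compound 3.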